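Removing a Methoxy Group from Two Related Cores

The source may hold more compounds than are shown below. What is called first, only, known or untested is meant among the compounds shown, and "the series" means these compounds.

Three compounds have been measured in a functional assay on HeLa cells (Homo sapiens) for inhibition, read by cell counting, with a stated time of 4 days; on this read-out higher numbers stand for weaker inhibition and lower numbers for stronger inhibition:
compound 1, `C=C(Br)C(=O)Nc1cccc(-c2cn3nc(Cc4cccc(OC)c4)sc3n2)c1`, gives 2500 nM
compound 2, `C=C(Br)C(=O)Nc1cccc(-c2cn3nc(Cc4ccccc4)sc3n2)c1`, gives 4500 nM
compound 3, `COc1ccc(-c2nn3cc(-c4cccc(N)c4)nc3s2)cc1OC`, gives 26000 nM

Compound 1 and compound 2 share one core; the change hydrogen in place of methoxy on an aromatic carbon gave a 1.8-fold higher number from compound 1 to compound 2 (0.26 log units; within the scatter). Compound 3 carries a different core, and the difference between the two cores is not broken down here; its number is the highest of the three.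

Compound 4, `COc1ccc(-c2nn3cc(-c4cccc(N)c4)nc3s2)cc1`, is not yet measured. It comes from compound 3 by the change (hydrogen in place of methoxy on an aromatic carbon), which sits ortho to a methoxy group, where the earlier change did not, so it is the same kind of change rather than the same one. Since the earlier step lay within the scatter, compound 4 is expected to show a small step as well, a 1.5-fold higher number from compound 3 to compound 4 (0.19 log units; within the scatter), resting on a 1.8-fold higher number from compound 1 to compound 2 (0.26 log units; within the scatter). Compound 4 is therefore estimated at 40000 nM, between 15000 nM and 100000 nM.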

Compound 4, half-maximal inhibitory concentration: >= 250000 nM
Compound 4: no number, only a limit; the forecaster's own chance of this, stated with the estimate: 25%; middle value at least 6.2-fold (0.79 log units) from the limit.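

In this assay, replacing the methoxy group with hydrogen gave an at least 9.6-fold higher number from compound 3 to compound 4 (0.98 log units; beyond the scatter), so the size of the step did not carry over from one core to the other: the same change on two cores in this assay, a 1.8-fold higher number (0.26 log units; within the scatter) from compound 1 to compound 2 and an at least 9.6-fold higher number (0.98 log units; beyond the scatter) from compound 3 to compound 4, at least 5.3-fold (0.72 log units) apart, beyond the scatter of two such steps

Compound 4 gives >= 250000 nM, which is a limit of the assay and not a number: the limit of >= 250000 nM in this assay, at which 1 of the 4 values shown sits.

These two pairs do not show whether the core or the place of the change matters more: on compound 3 the lost group sits ortho to a methoxy group, and on compound 1 it does not.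

On these data alone, it remains open how a hydroxyl or an ethoxy group would behave at this place on compound 3. Whether the same holds on the core of compound 1 is open too.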